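Quinazoline-ether phthalazinone amides: aryl para-substituent step

The compounds below may be only part of what the source reports. "The series", "measured", "known", "first", "only" and "open" are said of these compounds alone.

Measured:
- compound 1 `COc1cc2c(Oc3ccc(NC(=O)c4nn(-c5ccc([N+](=O)[O-])cc5)c(=O)c5ccccc45)cc3F)ccnc2cc1OCCCN1CCCC1`: 1240 nM
- compound 2 `COc1cc2c(Oc3ccc(NC(=O)c4nn(-c5ccc(F)cc5)c(=O)c5ccccc45)cc3F)ccnc2cc1OCCCN1CCN(C)CC1`: 91 nM
- compound 3 `COc1cc2c(Oc3ccc(NC(=O)c4nn(-c5ccc(Br)cc5)c(=O)c5ccccc45)cc3F)ccnc2cc1OCCCN1CCN(C)CC1`: 250 nM

In a functional assay on NCI-H460 cells (Homo sapiens) for cytotoxicity, read by MTT assay, with a stated time of 72 h (on this read-out higher numbers stand for weaker inhibition and lower numbers for stronger inhibition), compound 3 stands second highest of the three numbers, nearer to compound 2 than to compound 1. Compound 4 `COc1cc2c(Oc3ccc(NC(=O)c4nn(-c5ccc([N+](=O)[O-])cc5)c(=O)c5ccccc45)cc3F)ccnc2cc1OCCCN1CCN(C)CC1` differs from compound 3 by nitro in place of bromo on an aromatic carbon. Among the measured compounds shown here, only one measured step bears on the para position of that phenyl: a 2.7-fold higher number from compound 2 to compound 3 (0.44 log units; beyond the scatter), a modest rise. Compound 1 also carries the nitro, but with another chain, so no single step to compound 4 exists; its value in this assay is the highest shown. Compound 4 is therefore expected to give a higher number than compound 3, a 2.0-fold higher number from compound 3 to compound 4 (0.30 log units; within the scatter), estimated at 500 nM with a range of 150 nM to 1600 nM.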

Compound 4, half-maximal inhibitory concentration: 980 nM
For compound 4 the middle estimate is 2.0-fold (0.29 log units) below the measured one; low and high end bracket the measured number.
By their numbers in this assay, from the lowest: compound 2; then compound 3; then compounds 4 and 1 (each within the scatter of the next).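

In this assay the change from 4-bromophenyl to 4-nitrophenyl gives a 3.9-fold higher number from compound 3 to compound 4 (0.59 log units; beyond the scatter) and extends the order on this position, with fluoro to nitro giving an 11-fold higher number from compound 2 to compound 4 (1.03 log units; beyond the scatter) overall. With nitro in place, 4-methylpiperazin-1-yl for pyrrolidin-1-yl gives a 1.3-fold lower number from compound 1 to compound 4 (0.10 log units; within the scatter) and so does not separate the two chain ends. No measurement at hand explains these steps.

Going by these compounds, whether a methoxy, an amine or a carboxylic acid on this phenyl would fall within the same order remains open. So does whether the two chain ends also match with fluoro or bromo.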